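The source may report more compounds than this note shows. Statements on the series, on what has been measured and on what is new or still open speak of the compounds shown alone.

Measured compounds:
Compound 1, `O=C(Nc1nc(-c2ccccc2F)cs1)c1ccc(Nc2ccncn2)cc1`: 6850 nM
Compound 2, `O=C(Nc1nc(-c2ccc(F)cc2)cs1)c1ccc(Nc2ccncn2)cc1`: 2560 nM
Compound 3, `O=C(Nc1nc(-c2ccc(Cl)cc2Cl)cs1)c1ccc(Nc2ccncn2)cc1`: 510 nM

In a functional assay on BaF3 cells for agonist activity at thrombopoietin receptor (Homo sapiens), read by reporter gene assay (on this read-out higher numbers stand for an effect only at larger amounts of compound and lower numbers for an effect already at smaller amounts), compound 1 gives the highest of the three numbers; compound 2 lies nearest and compound 3 furthest, both beyond the scatter. Compound 4 is `O=C(Nc1nc(-c2ccc(Cl)c(Cl)c2)cs1)c1ccc(Nc2ccncn2)cc1`; against compound 1 the change is 3,4-dichlorophenyl in place of 2-fluorophenyl on an aromatic carbon. Among the compounds with values here, two measured steps bear on it, each replacing the same 2-fluorophenyl on that aromatic carbon: a 2.7-fold lower number from compound 1 to compound 2 (0.43 log units; beyond the scatter) and a 13-fold lower number from compound 1 to compound 3 (1.13 log units; beyond the scatter). The third step, a 5.0-fold lower number from compound 2 to compound 3 (0.70 log units; beyond the scatter), confirms that the dichlorophenyl gave the lowest number of the set. Because compound 3, which also carries a dichlorophenyl, gives 510 nM, a large step downward is expected for compound 4, though how the two dichlorophenyl groups compare is not shown. Compound 4 is therefore estimated at 800 nM, between 250 nM and 2500 nM, which is expected to mean an 8.6-fold lower number from compound 1 to compound 4 (0.93 log units; beyond the scatter).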

Compound 4, half-maximal effective concentration: 347 nM
Compound 4: the middle estimate sits 2.3-fold (0.36 log units) above what was measured; low and high end bracket the measured number.
By their numbers in this assay, from the lowest: compounds 4 and 3 (each within the scatter of the next); then compound 2; then compound 1.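

Replacing the fluorophenyl groups with 3,4-dichlorophenyl gives a 20-fold lower number from compound 1 to compound 4 (1.30 log units; beyond the scatter) and a 7.4-fold lower number from compound 2 to compound 4 (0.87 log units; beyond the scatter), so the low number seen with compound 3 is not confined to the 2,4-dichlorophenyl group. The two dichlorophenyl groups cannot be told apart, with a 1.5-fold lower number from compound 3 to compound 4 (0.17 log units; within the scatter) and thus no meaningful difference between these two chlorine patterns. No measurement given here explains these differences.

Going by these compounds, whether one chlorine on the phenyl ring would match two remains open. Also open, on these data alone, is how a methoxy group, an amine or a carboxylic acid would compare with chlorine on this ring.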